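Adding One Methyl Group, With a Flat Step Expected

A few compounds are considered here, and "the series" means these few. Any claim that something is new, unique, unknown or untested is made for them only; others in the source may bear on it.

Measured compounds:
compound 1 `COc1nsnc1C(=O)Nc1cc(C(F)(F)F)cc(C(F)(F)F)c1`: -1.9%
compound 2 `Cn1cc(C(=O)Nc2cc(C(F)(F)F)cc(C(F)(F)F)c2)c(O)n1`: 7.23%

Of the compounds shown here, two have been measured in an assay on isolated protein for inhibition of mitogen-activated protein kinase kinase kinase 14 (Homo sapiens), read by ADP-Glo, with a stated time of 60 min, tested at 100 uM, in the presence of a further agent that is not named here; a higher number here means more inhibition at the concentration tested (going by the name of the read-out), a lower number less inhibition. Compound 1 gives -1.9% in this assay. Compound 2 gives 7.23% in this assay. Going by the values given here, compound 2 has the higher of the two numbers, but the only measured step, a number 9.1 percentage points higher from compound 1 to compound 2 (within the scatter), lies within the scatter, so the two compounds cannot be separated on these numbers; they differ in the whole five-membered ring that sits on the carbonyl carbon.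

Compound 3 `Cc1c(C(=O)Nc2cc(C(F)(F)F)cc(C(F)(F)F)c2)c(O)nn1C` is not yet measured. It differs from compound 2 in one place: methyl in place of hydrogen on an aromatic carbon. Among the compounds with values here, no measured step concerns the addition of a methyl group, and the one measured step concerns a different change, the exchange of one ring for another, and was itself within the scatter. There is therefore no basis for expecting a step beyond the scatter in this assay in either direction; the expected step of a number 0.8 percentage points higher from compound 2 to compound 3 (within the scatter) is essentially flat. The estimate for compound 3 in this assay is 8%, with a range from -6% to 22%.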

Compound 3, a percentage reported as inhibition, at one concentration (the size of the read-out at that concentration, not a potency): 24.1%
Estimate against measurement, compound 3: 16.1 percentage points below; measured number above the stated range.
By their numbers in this assay, from the lowest: compounds 1 and 2 (each within the scatter of the next); then compound 3.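

In this assay, methyl in place of hydrogen on an aromatic carbon, on the ring atom next to the ring nitrogen, gives a number 16.9 percentage points higher from compound 2 to compound 3 (beyond the scatter), so this is a position where a single added carbon shifts the read-out beyond the scatter. With that methyl in place, the exchange of the group on the carbonyl carbon also becomes readable, as a number 26 percentage points higher from compound 1 to compound 3 (beyond the scatter), although that step changes the whole ring and cannot be credited to the methyl alone. Nothing available bears on why the methyl has this effect.

On these data alone, it remains open whether the rise is specific to methyl or would also follow from an ethyl group, a chlorine atom or an amine on the same carbon. Compound 3 gives 24.1% at a single tested concentration, which is the size of a read-out and not a potency, so the actual strength of inhibition across these compounds is also unsettled.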